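Thiophene for thiazole on the pyrazoline carbon

The source may report more compounds than this note shows. Statements on the series, on what has been measured and on what is new or still open speak of the compounds shown alone.

Within the data shown here, compound 1 `CC(=O)N1N=C(c2cc(O)c(O)c([N+](=O)[O-])c2)CC1c1nccs1` is one of two compounds measured in an assay on isolated protein for inhibition of Amine oxidase [flavin-containing] B (Homo sapiens), read by fluorescence (on this read-out lower numbers stand for stronger inhibition and higher numbers for weaker inhibition), where compound 1 gives 68200 nM. Among the measured compounds shown here, the only other measured compound is compound 2 `N#Cc1cccc(/C=C/C(=O)c2cc(O)c(O)c([N+](=O)[O-])c2)c1`, which in this assay gives 60600 nM; the two numbers lie within the scatter of each other, so nothing separates them, and no step between them is counted.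

The next compound, compound 3 `CC(=O)N1N=C(c2cc(O)c(O)c([N+](=O)[O-])c2)CC1c1cccs1`, keeps the core of compound 1 and changes one place: thiophen-2-yl in place of 1,3-thiazol-2-yl on a saturated ring carbon. For the measured compounds named here, no measured pair shows the effect of such a swap, so the expectation rests on the unchanged remainder of compound 1. The step from compound 1 to compound 3 is expected to be a 1.1-fold lower number from compound 1 to compound 3 (0.06 log units; within the scatter), that is, none beyond the scatter in either direction. Compound 3 is therefore estimated at 60000 nM in this assay, with a range from 25000 nM to 150000 nM.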

Compound 3, half-maximal inhibitory concentration: 69200 nM
Estimate against measurement, compound 3: 1.2-fold (0.06 log units) below; the measured number falls inside the stated range.
By their numbers in this assay, from the lowest: compounds 2, 1 and 3 (each within the scatter of the next).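

Exchanging 1,3-thiazol-2-yl for thiophen-2-yl on the saturated ring carbon gives, in this assay, a 1.0-fold higher number from compound 1 to compound 3 (0.01 log units; within the scatter). Among these compounds, this is the first step read at this position: the entering group has one hetero atom and one hydrogen-bond acceptor fewer, and the number stays within the scatter. The ring nitrogen of the 1,3-thiazol-2-yl group is therefore not required to hold the level of compound 1, though that level is itself a high number on this read-out, and nothing measured here bears on why the swap leaves it in place. Going by these compounds, whether an amine, a carboxylic acid or a longer chain on this saturated ring carbon would move the number beyond the scatter remains open. Also open, on these data alone, is whether a change at the acetyl group would do so.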